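Aryl substituent changes in a lysosomal alpha-glucosidase inhibitor series

A few compounds are considered here, and "the series" means these few. Any claim that something is new, unique, unknown or untested is made for them only; others in the source may bear on it.

Compounds measured so far:
compound 1 `Cc1ccc(N2CCN(S(=O)(=O)c3ccc4c(c3)CC(=O)N4)CC2)cc1` — "not active" (no number reported)
compound 2 `O=C1Cc2cc(S(=O)(=O)N3CCN(c4ccc([N+](=O)[O-])cc4)CC3)ccc2N1` — 3260 nM
compound 3 `O=C1Cc2cc(S(=O)(=O)N3CCN(c4ccc(Cl)cc4)CC3)ccc2N1` — 94300 nM

Working notes. In an assay on isolated protein for inhibition of lysosomal alpha-glucosidase (Homo sapiens), read by fluorescence, with stated times of 5 min and 45 min (a lower number here means a stronger inhibitor, a higher number a weaker inhibitor), compound 1 is reported as "not active" (no number reported), with no number given. Compound 2 gives 3260 nM and compound 3 gives 94300 nM. Within the data shown here, compound 3 stands highest of the two numbered entries; its nearest neighbour is compound 2, and the single one-place step known, a 29-fold higher number from compound 2 to compound 3 (1.46 log units; beyond the scatter), is large.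

The next compound, compound 4 `O=C1Cc2cc(S(=O)(=O)N3CCN(c4ccc(C(F)(F)F)cc4)CC3)ccc2N1`, differs from compound 3 as follows: trifluoromethyl in place of chloro on an aromatic carbon. Among the measured compounds shown here, no measured pair covers trifluoromethyl against chloro, so the only step that bears on it is a 29-fold higher number from compound 2 to compound 3 (1.46 log units; beyond the scatter), which shows the number at this position can move strongly. That step does not point to a direction for the present change. Compound 4 is therefore expected to give a number near that of compound 3, with a step of a 1.6-fold lower number from compound 3 to compound 4 (0.20 log units; within the scatter) in this assay, and compound 4 is estimated at 60000 nM within 15000 nM to 250000 nM.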

Compound 4, half-maximal inhibitory concentration: "not active" (no number reported)
Nothing numeric was reported for compound 4; there is nothing to compare the estimate with.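

In this assay, among these compounds, compound 4 gives "not active" (no number reported), so no step between compound 3 and compound 4 can be read. No measurement shown bears on the reason for this result. The compounds shown leave open how trifluoromethyl compares numerically with chloro or nitro on this aromatic carbon.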